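The source may hold more compounds than are shown below. What is called first, only, known or untested is meant among the compounds shown, and "the series" means these compounds.

Measured compounds:

compound 1 `O=C(/C=C/c1ccc(Cn2cc(Nc3ncc(Cl)c(Nc4ccc(F)cc4)n3)cn2)cc1)NO` — 63 nM
compound 2 `O=C(CCCCCCn1cc(Nc2ncc(Cl)c(Nc3cccc(Cl)c3)n2)cn1)NO` — 41 nM

Both compounds were read in an assay on isolated protein for inhibition of protein deacetylase HDAC6 (Homo sapiens), read by fluorescence, with stated times of 5 min and 30 min; a lower number here means a stronger inhibitor, a higher number a weaker inhibitor. Compound 2 gives 41 nM and has the lowest of the two numbers; its nearest neighbour is compound 1 with 63 nM, a gap that lies within the scatter, so no order between the two can be claimed. Within the data shown here, the two differ in more than one place, so no single step between them is counted.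

Compound 3 `CNc1nc(Nc2cnn(CCCCCCC(=O)NO)c2)ncc1Cl` has not yet been measured in this assay . Its difference from compound 2 is methyl in place of 3-chlorophenyl on a nitrogen on an aromatic ring. The change removes the only aromatic ring on that nitrogen and replaces it with a single carbon; the hydroxamic acid and its six-carbon chain, and the rest of the shared core, are kept unchanged. Among the measured compounds shown here, no measured pair shows what such a change does here, so the expectation rests on compound 2 alone.

The expectation for compound 3 is a somewhat higher number than compound 2, a step of a 2.9-fold higher number from compound 2 to compound 3 (0.47 log units; beyond the scatter), modest and possibly no more than the scatter. Compound 3 is estimated at 120 nM, within a range of 40 nM to 400 nM.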

Compound 3, half-maximal inhibitory concentration: 29 nM
Estimate against measurement, compound 3: 4.1-fold (0.62 log units) above, and the stated range ends above it.
By their numbers in this assay, from the lowest: compounds 3, 2 and 1 (each within the scatter of the next, the first and the last beyond it).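

In this assay, methyl in place of 3-chlorophenyl on a nitrogen on an aromatic ring gives a 1.4-fold lower number from compound 2 to compound 3 (0.15 log units; within the scatter) and so sets no order between the two compounds. Among these compounds, this is the first single-place step, and it shows that the 3-chlorophenyl group, with its one six-membered aromatic ring and 7 heavy atoms, can give way to methyl, with 1 heavy atom, without a step beyond the scatter, so the aromatic ring on this nitrogen is not needed for a number in this range while the rest of compound 2 is kept. No accompanying data bear on why the step is this small.

Open, going by these compounds, is what happens between and beyond these two extremes on the same nitrogen: an ethyl, a cyclopropyl, an unsubstituted phenyl, a free amine or a chain ending in a carboxylic acid could each fall in this range or outside it. Also open, on these data alone, is whether the methylamino group behaves the same way with a shorter or a longer chain carrying the hydroxamic acid.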